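Pyridinone amides on HepG2: trifluoromethylphenyl for methylphenyl

A few compounds are considered here, and "the series" means these few. Any claim that something is new, unique, unknown or untested is made for them only; others in the source may bear on it.

Two compounds of the series carry a measured number in a functional assay on HepG2 cells (Homo sapiens) for cytotoxicity, read by MTT assay, with a stated time of 72 h; on this read-out lower numbers stand for stronger inhibition and higher numbers for weaker inhibition. Compound 1 `Cn1ccc2c(Oc3ccc(NC(=O)c4nn(-c5ccc(Cl)c(C(F)(F)F)c5)ccc4=O)cc3)ccnc21` gives 23400 nM in this assay. Compound 2 `Cc1ccc(-n2nc(C(=O)Nc3ccc(Oc4ncnc5[nH]ccc45)cc3)c(C)cc2=O)cc1` gives 7460 nM in this assay, the lowest of the two numbers; compound 1 stands at a higher number, and that gap lies beyond the usual scatter. Among the measured compounds shown here, no pair of measured compounds differs in one place, so no single-point step is known.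

Compound 3 `Cc1cc(=O)n(-c2cccc(C(F)(F)F)c2)nc1C(=O)Nc1ccc(Oc2ncnc3[nH]ccc23)cc1` is not yet measured. It differs from compound 2 by 3-(trifluoromethyl)phenyl in place of 4-methylphenyl on an aromatic nitrogen. For the measured compounds named here, nothing among the measured compounds isolates this exchange, so no direction can be read from the data.

The step from compound 2 to compound 3 is therefore expected to be small, a 1.1-fold lower number from compound 2 to compound 3 (0.06 log units; within the scatter), with no change beyond the scatter the most likely outcome. On that basis compound 3 is estimated at 6500 nM in this assay, within a range of 2200 nM to 19000 nM.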

Compound 3, half-maximal inhibitory concentration: 9470 nM
Compound 3: middle estimate off by 1.5-fold (0.16 log units), on the low side; the range from low to high includes it.
By their numbers in this assay, from the lowest: compounds 2 and 3 (each within the scatter of the next); then compound 1.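

In this assay the series now has its first single-point step, a 1.3-fold higher number from compound 2 to compound 3 (0.10 log units; within the scatter), for 3-(trifluoromethyl)phenyl in place of 4-methylphenyl on an aromatic nitrogen. At this position the exchange adds three fluorine atoms and moves the substituent to a different place on the phenyl ring, yet the two compounds cannot be told apart beyond the scatter, so this position accepts both groups in this read-out. No measurement at hand explains why the two groups read alike, and the result stands without a stated cause.

The exchange alters the substituent and its place on the phenyl ring together, so compound 2 and compound 3 cannot separate those two parts. Going by these compounds, it remains open whether an unsubstituted phenyl, a plain methyl, or a phenyl bearing an amine or a carboxylic acid on this nitrogen would stay within the scatter of compound 2 in this assay, or whether this position responds only to larger departures from the two groups seen so far.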